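The source may hold more compounds than are shown below. What is called first, only, known or untested is meant among the compounds shown, and "the series" means these compounds.

Working notes on the series. The shared core of compound 1 `Cn1c(Cc2nn(C)c(=O)c3ccccc23)nnc1SCCCCCCCC(=O)Nc1ccc(O)cc1` carries an amide whose nitrogen bears a 4-hydroxyphenyl group at the end of the long chain. In an assay on isolated protein (Mus musculus) for inhibition of IL15-IL15 receptor (Homo sapiens), read by resazurin assay, with stated times of 30 min and 2.5 days (on this read-out higher numbers stand for weaker inhibition and lower numbers for stronger inhibition), compound 1 returns only a limit of the assay, > 30000 nM, and so stands without a number among the three measured values (the limit of > 30000 nM in this assay, at which 1 of the 3 values shown sits). Compound 2 `CC(C)COc1ccc(NC(=O)CSc2nnc(Cc3nn(C)c(=O)c4ccccc34)n2C)cc1` gives 30000 nM in this assay. Compound 3 `Cn1c(Cc2nn(C)c(=O)c3ccccc23)nnc1SCC(=O)Nc1ccc(Cl)cc1Cl` gives 17300 nM in this assay. For the measured compounds named here, the one measured step, a 1.7-fold lower number from compound 2 to compound 3 (0.24 log units; within the scatter), swaps a 4-(isobutoxy)phenyl for a 2,4-dichlorophenyl on the amide-type nitrogen and stays within the scatter.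

Compound 4 `Cn1c(Cc2nn(C)c(=O)c3ccccc23)nnc1SCCCCCCCC(=O)Nc1ccc(F)cc1F` differs from compound 1 by 2,4-difluorophenyl in place of 4-hydroxyphenyl on an amide-type nitrogen. The nearest measured precedent is the step from compound 2 to compound 3, a halogenated phenyl replacing an oxygen-substituted phenyl on the same kind of nitrogen, which gave no change beyond the scatter. On that basis no step beyond the scatter is expected from compound 1 to compound 4, a number no higher from compound 1 to compound 4 (the limit leaves the size open). Compound 4 is therefore estimated at 30000 nM in this assay, with a range from 10000 nM to 100000 nM.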

Compound 4, half-maximal inhibitory concentration: 2300 nM
For compound 4 the middle estimate is 13-fold (1.12 log units) above the measured one; measured number outside the range, below it.
By their numbers in this assay, from the lowest: compound 4; then compounds 3 and 2 (each within the scatter of the next).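

On an amide-type nitrogen, the aryl group can matter in this assay: 2,4-difluorophenyl in place of 4-hydroxyphenyl gives an at least 13-fold lower number from compound 1 to compound 4 (1.11 log units; beyond the scatter). The earlier swap on this kind of nitrogen, between compound 2 and compound 3, stayed within the scatter, so this is the first change in the series shown to move the number beyond it. The step has only a lower bound, since compound 1 has a limit and not a number: the limit of > 30000 nM in this assay, at which 1 of the 4 values shown sits.

The compounds shown do not separate the loss of the hydroxyl from the entry of the two fluorines, and a plain phenyl or a 4-fluorophenyl on this nitrogen would tell these apart. Also open, from the compounds shown here alone, are whether 2,4-difluorophenyl gives a similar number on a shorter chain and what an amine or a carboxylic acid on the phenyl ring would give.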